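Cyclohexyl to 4-Nitrophenyl on a Tetrahydropyran Side Chain

This account rests on a few compounds, and the source may have more. Where it says the series, first, only, none or still open, it means among the compounds named here.

Measured compounds:
compound 1 `COc1ccc(/C=C/C[C@@H]2C[C@@H]([C@@H](O)c3ccc(OC)c(OC)c3)CO[C@H]2c2ccc(OC)c(OC)c2)cc1OC` — 26000 nM
compound 2 `O[C@@H](c1ccccc1)[C@H]1CO[C@H](c2ccccc2)[C@@H](C/C=C/C2CCCCC2)C1` — 6260 nM
compound 3 `COc1ccc(/C=C/C[C@@H]2C[C@H]([C@H](O)c3ccc(OC)c(OC)c3)CO[C@H]2c2ccc(OC)c(OC)c2)cc1OC` — "not determined" (no result reported)

Compounds 1, 2 and 3 were tested in a functional assay on HL-60 cells (Homo sapiens) for cytotoxicity, read by WST assay, with a stated time of 48 h; on this read-out lower numbers stand for stronger inhibition and higher numbers for weaker inhibition. In this assay compound 1 gives 26000 nM, while compound 2 gives 6260 nM. For compound 3 this assay reports "not determined" (no result reported), so no number is available for it; compound 3 is related to compound 1 by the fact that compounds 1 and 3 differ only in the configuration as drawn. Of the two numbers shown, compound 2 has the lower one, and its gap to compound 1 lies beyond the usual scatter of this kind of measurement.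

Compound 4 `O=[N+]([O-])c1ccc(/C=C/C[C@H]2C[C@@H]([C@@H](O)c3ccccc3)CO[C@@H]2c2ccccc2)cc1` has not yet been tested. It differs from compound 2 in one place: 4-nitrophenyl in place of cyclohexyl on a double-bonded chain carbon bound to a double-bonded chain carbon. For the measured compounds named here, no pair of measured compounds shows what this change does, so there is no measured step to lean on.

Going by the values given here, the step from compound 2 to compound 4 in this assay is expected to be a 1.3-fold lower number from compound 2 to compound 4 (0.10 log units; within the scatter), a modest shift with wide uncertainty, because compound 2 stands at 6260 nM and nothing among the measured compounds tests the 4-nitrophenyl group. Compound 4 is therefore estimated at 5000 nM, with a range from 1500 nM to 16000 nM.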

Compound 4, half-maximal inhibitory concentration: 4880 nM
For compound 4 the middle estimate is 1.0-fold (0.01 log units) above the measured one, within the range that was stated.
By their numbers in this assay, from the lowest: compounds 4 and 2 (each within the scatter of the next); then compound 1.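

In this assay, for the compounds shown here, placing 4-nitrophenyl in place of cyclohexyl on a double-bonded chain carbon bound to a double-bonded chain carbon gives a 1.3-fold lower number from compound 2 to compound 4 (0.11 log units; within the scatter), the first measured step at this place on the chain, and it leaves the two compounds indistinguishable on this read-out. At this place, then, a six-membered non-aromatic ring of carbon only and a six-membered aromatic ring bearing a nitro group give numbers that cannot be told apart, even though the exchange adds heavy atoms and hydrogen-bond acceptors. Nothing in the available evidence bears on why the numbers stay so close.

What the compounds shown leave open is whether this holds for other groups at the same place, such as a 4-aminophenyl group, a 4-carboxyphenyl group or a longer open alkyl chain. They also leave open whether the exchange of cyclohexyl for 4-nitrophenyl would give a similar result on a core carrying methoxy groups on its aromatic rings, as in compound 1.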